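Single-point screen of a dihydropyrimidine ester series

This account rests on a few compounds, and the source may have more. Where it says the series, first, only, none or still open, it means among the compounds named here.

Measured so far:
compound 1, `CC1=C(C(=O)OC(C)C)[C@H](c2ccco2)N/C(=N/C#N)N1`: 1%
compound 2, `CCOC(=O)C1=C(C)N/C(=N\C#N)NC1c1ccsc1`: 23%
compound 3, `CC1=C(C(=O)OC(C)C)[C@@H](c2ccco2)N/C(=N/C#N)N1`: 4%

In an assay on HeLa cells for displacement of a labelled ligand from adenosine receptor A3 (Homo sapiens), with a stated time of 180 min, tested at 1 uM (on this read-out higher numbers stand for more inhibition at the one concentration tested (going by the name of the read-out) and lower numbers for less inhibition), compound 2 gives 23%, the highest of the three numbers; the nearest is compound 3 with 4%, a gap beyond the scatter, and the furthest is compound 1 with 1%, also beyond the scatter. Among the measured compounds shown here, the only pairwise step measured is a number 3 percentage points higher from compound 1 to compound 3 (within the scatter), which rests on the fact that compounds 1 and 3 differ only in the configuration as drawn and says nothing about a change of the group on the saturated ring carbon.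

Compound 4, `CCOC(=O)C1=C(C)N/C(=N\C#N)NC1C1CCCC1`, is not yet measured. It differs from compound 2 by cyclopentyl in place of thiophen-3-yl on a saturated ring carbon. For the measured compounds named here, no measured step bears on this exchange: the one step available concerns configuration only, and the difference between compound 2 and compound 3 mixes two changes at once. In this assay the expectation for compound 4 is therefore anchored on compound 2 alone, with a wide range, and is estimated at 15% (from 0% to 35%). This estimate means an expected step of a number 8 percentage points lower from compound 2 to compound 4 (within the scatter), which is within the scatter and sets no direction with confidence.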

Compound 4, a percentage reported as inhibition, at one concentration (the size of the read-out at that concentration, not a potency): 4%
Beside the measured number, compound 4's estimate is 11 percentage points above it, and the stated range covers the measured number.
By their numbers in this assay, from the lowest: compounds 1, 3 and 4 (each within the scatter of the next); then compound 2.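

In this assay, among the compounds shown here, the exchange of thiophen-3-yl for cyclopentyl on the saturated ring carbon gives the only measured step in which the group at this position changes, rather than its configuration: a number 19 percentage points lower from compound 2 to compound 4 (beyond the scatter). The two groups have the same heavy-atom count and both are five-membered rings, yet the number is lower with cyclopentyl; the step separates a five-membered aromatic ring with a sulfur from a non-aromatic ring of carbon only. The one fact at hand concerns configuration alone and does not bear on this exchange, so nothing here accounts for the step.

The compounds shown do not separate the loss of the ring sulfur from the loss of aromaticity, and a phenyl or pyridyl group or a tetrahydrothiophenyl ring on the same carbon would be needed to pull these apart. Also open, as far as these compounds go, are how an open-chain group such as isobutyl or a group carrying an amine would read at this position, and whether the single-concentration numbers for compound 2 and compound 4 would hold as a difference in potency.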